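The source may hold more compounds than are shown below. What is called first, only, known or untested is meant among the compounds shown, and "the series" means these compounds.

Working notes on the series. Compound 1 `COc1ccc(Br)cc1CCc1c(Cl)cccc1-c1nccn1C` gives 300 nM in an assay on isolated protein for binding affinity to Melanocortin receptor 4 (Homo sapiens); a lower number here means a stronger inhibitor, a higher number a weaker inhibitor. Compound 2 `CCn1ccnc1-c1cccc(Cl)c1CCc1cc(Br)ccc1OC` gives 310 nM in this assay, the step of a 1.0-fold higher number from compound 1 to compound 2 (0.01 log units; within the scatter) being flat. Compound 3 `CCCn1ccnc1-c1cccc(Cl)c1CCc1cc(Br)ccc1OC` gives 1300 nM in this assay, the highest of the three numbers: it is set apart from compound 2 by a 4.2-fold higher number from compound 2 to compound 3 (0.62 log units; beyond the scatter) and from compound 1 by a 4.3-fold higher number from compound 1 to compound 3 (0.64 log units; beyond the scatter), so each added chain carbon so far has cost a modest amount once the chain passes methyl.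

Compound 4 `CCC(C)n1ccnc1-c1cccc(Cl)c1CCc1cc(Br)ccc1OC` has not yet been measured. It differs from compound 3 by methyl in place of hydrogen on a saturated chain carbon bound to an aromatic nitrogen and a saturated chain carbon; cut one bond further out this reads propyl to sec-butyl. Going by the values given here, two measured steps bear on it. The step of a 1.0-fold higher number from compound 1 to compound 2 (0.01 log units; within the scatter) shows that one added methyl on the carbon bound to the aromatic nitrogen is tolerated, while a 4.2-fold higher number from compound 2 to compound 3 (0.62 log units; beyond the scatter) and a 4.3-fold higher number from compound 1 to compound 3 (0.64 log units; beyond the scatter) show that added chain carbons beyond that cost a modest amount. Compound 4 adds its methyl at the tolerated position but onto a chain that already carries the penalised extension, so a small step toward a higher number, at most of the size seen in a 4.2-fold higher number from compound 2 to compound 3 (0.62 log units; beyond the scatter), is expected in this assay. For compound 4 the estimate is therefore 2000 nM, within 800 nM to 5000 nM, an expected step of a 1.5-fold higher number from compound 3 to compound 4 (0.19 log units; within the scatter).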

Compound 4, inhibition constant: 2500 nM
Compound 4: the middle estimate sits 1.3-fold (0.10 log units) below what was measured, and the stated range covers the measured number.
By their numbers in this assay, from the lowest: compounds 1 and 2 (each within the scatter of the next); then compounds 3 and 4 (each within the scatter of the next).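

In this assay, the methyl on the saturated chain carbon bound to an aromatic nitrogen and a saturated chain carbon gives a 1.9-fold higher number from compound 3 to compound 4 (0.28 log units; within the scatter), so propyl to sec-butyl stays within the scatter, and this methyl reads alike whether the chain is short or already extended: the same change on two cores in this assay, a 1.0-fold higher number (0.01 log units; within the scatter) from compound 1 to compound 2 and a 1.9-fold higher number (0.28 log units; within the scatter) from compound 3 to compound 4, 1.9-fold (0.27 log units) apart, within the scatter of two such steps

The ethyl addition on the shared core also holds up on a second background, with an 8.1-fold higher number from compound 2 to compound 4 (0.91 log units; beyond the scatter) now standing beside the earlier step on compound 1 and compound 3: the same change on two cores in this assay, a 4.3-fold higher number (0.64 log units; beyond the scatter) from compound 1 to compound 3 and an 8.1-fold higher number (0.91 log units; beyond the scatter) from compound 2 to compound 4, 1.9-fold (0.27 log units) apart, within the scatter of two such steps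

Taken whole, sec-butyl in place of methyl on the aromatic nitrogen gives an 8.3-fold higher number from compound 1 to compound 4 (0.92 log units; beyond the scatter), so in this small set the substituents that carry the larger ethyl addition, in compound 3 and compound 4, sit beyond the scatter from the methyl of compound 1, while the added methyl alone does not move the number beyond the scatter in either pair.

Going by these compounds, whether a longer chain such as n-butyl, or a tert-butyl or cyclopropyl group, on the aromatic nitrogen would continue this trend remains open. So does the response to a chain bearing a hydroxyl group or an amine at this position.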